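The source may hold more compounds than are shown below. What is called first, only, known or untested is meant among the compounds shown, and "the series" means these compounds.

- Compound 1 `O=C(/C=C/c1ccc2c(c1)CN(S(=O)(=O)c1cccs1)C2)NO`: 800 nM
- Compound 2 `O=C(/C=C/c1ccc2c(c1)CN(S(=O)(=O)c1cccc(C(F)(F)F)c1)C2)NO`: 2050 nM

In a functional assay on HCT-116 cells (Homo sapiens) for antiproliferative activity (a lower number here means a stronger inhibitor, a higher number a weaker inhibitor), compound 2 gives 2050 nM, the highest of the two numbers and therefore the weaker result. Its gap to compound 1 lies beyond the usual scatter of repeat measurements.

Compound 3 `COc1cccc(S(=O)(=O)N2Cc3ccc(/C=C/C(=O)NO)cc3C2)c1` has methoxy in place of trifluoromethyl on an aromatic carbon, meta to a large group: methoxy in place of trifluoromethyl on an aromatic carbon. Among the measured compounds shown here, no measured pair shows this change on its own, so any forecast is loose. The only other reference point is compound 1 at 800 nM, which lies lower, so a modest drop is expected rather than a rise, and it may stay within the scatter. The estimated move is a 1.7-fold lower number from compound 2 to compound 3 (0.23 log units; within the scatter). The estimate for compound 3 is 1200 nM, with an expected range from 400 nM to 3500 nM.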

Compound 3, half-maximal inhibitory concentration: 1130 nM
For compound 3 the middle estimate is 1.1-fold (0.03 log units) above the measured one, within the range that was stated.
By their numbers in this assay, from the lowest: compounds 1, 3 and 2 (each within the scatter of the next, the first and the last beyond it).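

Read in this assay the exchange of trifluoromethyl for methoxy on this aromatic carbon gives a 1.8-fold lower number from compound 2 to compound 3 (0.26 log units; within the scatter) so bringing a hydrogen-bond acceptor to this position does not move the number clear of the scatter. Setting 3-methoxyphenyl in place of thiophen-2-yl on the sulfonyl sulfur gives a 1.4-fold higher number from compound 1 to compound 3 (0.15 log units; within the scatter) so, with methoxy on it, a six-membered aromatic ring on that sulfur cannot be told apart from compound 1 in this measurement. Nothing available here explains these numbers.

From the compounds shown here alone, it remains open whether an amine or a carboxylic acid on this same aromatic carbon would shift the number beyond the scatter, in either direction. The compounds shown also leave open how a longer chain, such as ethoxy, would compare with methoxy here.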